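Maximal response in the series: ester in place of acid

The source may report more compounds than this note shows. Statements on the series, on what has been measured and on what is new or still open speak of the compounds shown alone.

Measured compounds:
compound 1, `COc1cc(C(=O)O)ccc1OCCCCOc1ccc(C(=O)CC(C)C)c(O)c1C`: 85.7%
compound 2, `Cc1c(OCCCCOc2ccc(C(=O)O)cc2)ccc(C(=O)CC(C)C)c1O`: 88%

Both measured compounds carry a carboxylic acid on the aryl ether end and the same acyl-phenol core. Among the measured compounds shown here, in an assay on HEK293 cells for positive allosteric modulation of metabotropic glutamate receptor 2 (Rattus norvegicus), read by thallium flux, with a stated time of 2.5 min (on this read-out lower numbers stand for smaller maximal responses and higher numbers for larger maximal responses), compound 1 gives 85.7% and compound 2 gives 88%; the one measured step, a number 2.3 percentage points higher from compound 1 to compound 2 (within the scatter), is within the scatter, so compound 2 and compound 1 cannot be told apart on this read-out, and compound 2 simply sits with compound 1 near the top of the range seen so far.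

Compound 3, `COC(=O)c1ccc(OCCCCOc2ccc(C(=O)CC(C)C)c(O)c2C)cc1`, is not yet measured. It differs from compound 2 by methyl in place of hydrogen on an oxygen next to a carbonyl group. For the measured compounds named here, no measured step touches this oxygen: the only step known, hydrogen in place of methoxy on an aromatic carbon, concerns a different part of the molecule, and its size, a number 2.3 percentage points higher from compound 1 to compound 2 (within the scatter), gives no lead on the ester. Going by the values given here, nothing in the two numbers so far points to a change beyond the scatter in this assay for this exchange.

Compound 3 is therefore expected to give about 85% in this assay, between 62% and 100%, an estimated step of a number 3 percentage points lower from compound 2 to compound 3 (within the scatter) that is not expected to exceed the scatter.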

Compound 3, largest response reached (reported as percent of maximum), in percent of the reference or control that the assay uses: 16.4%
Estimate against measurement, compound 3: 68.6 percentage points above; measured number outside the range, below it.
By their numbers in this assay, from the lowest: compound 3; then compounds 1 and 2 (each within the scatter of the next).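

Working notes: the carboxy group of compound 2 cannot be exchanged freely for methoxycarbonyl, since in this assay methyl in place of hydrogen on this oxygen gives a number 71.6 percentage points lower from compound 2 to compound 3 (beyond the scatter) and so most of the maximal response is lost. Among the compounds shown here, the only earlier step, a number 2.3 percentage points higher from compound 1 to compound 2 (within the scatter) on an aromatic carbon, showed no such sensitivity, so this is the first sign that a single change can move the read-out beyond the scatter, here with just one added carbon at the 4-carboxyphenyl end. The data at hand offer no measurement that explains the drop.

From the compounds shown here alone, it remains open whether the drop is specific to the methyl ester or would follow any replacement of the carboxylic acid, and a primary amide, a tetrazole or an ethyl ester at the same place would help to separate these cases. Going by these compounds, it is also open whether the same exchange on compound 1, with its methoxy group on the aromatic ring, would give a step of similar size.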